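This account rests on a few compounds, and the source may have more. Where it says the series, first, only, none or still open, it means among the compounds named here.

Compound 1 `C=C1C[C@]23C[C@@]1(O)CC[C@H]2c1ccc(O)c(C)c1[C@@H]3Cn1cc(-c2ccc(C(F)(F)F)cc2)nn1` gives 8950 nM in a functional assay on HL-60 cells (Homo sapiens) for cytotoxicity, read by MTT assay, with a stated time of 4 days; a higher number here means a weaker inhibitor, a lower number a stronger inhibitor.
Compound 2 `C=C1C[C@]23C[C@@]1(O)CC[C@H]2c1ccc(O)c(C)c1[C@@H]3Cn1cc(-c2ccc(Br)cc2)nn1` reaches only the limit > 20000 nM in this assay.
Compound 3 `C=C1C[C@]23C[C@@]1(O)CC[C@H]2c1ccc(O)c(C)c1[C@@H]3Cn1cc(-c2ccc(F)cc2)nn1` likewise reaches only the limit > 20000 nM in this assay.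

Compound 3 therefore stands at a limit, not at a number, a position described by the limit of > 20000 nM in this assay, at which 2 of the 3 values shown sit. Compound 4 `C=C1C[C@]23C[C@@]1(O)CC[C@H]2c1ccc(O)c(C)c1[C@@H]3Cn1cc(-c2ccc(C)cc2)nn1` differs from compound 3 by methyl in place of fluoro on an aromatic carbon. Going by the values given here, two measured steps touch this position: an at least 2.2-fold higher number from compound 1 to compound 3 (0.34 log units; beyond the scatter) shows that swapping trifluoromethyl for fluoro weakened the compound at least modestly, while a step that the two limits leave unreadable from compound 2 to compound 3 cannot be read, both of its ends sitting at the limit. Methyl, like fluoro and bromo, is a single-atom group, so compound 4 is expected to remain weak, most likely again as a limit. The expected change is a step that the limit leaves unreadable from compound 3 to compound 4. Compound 4 is estimated at 25000 nM, ranging from 8000 nM to 60000 nM.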

Compound 4, half-maximal inhibitory concentration: > 20000 nM
Compound 4 gave a limit, no number; the forecaster's own chance of this, stated with the estimate: 70%; the middle value does not contradict the limit.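

Compound 4 also stands at a limit, so a carbon-based group as small as methyl fares no better here than the two halogens: the limit of > 20000 nM in this assay, at which 3 of the 4 values shown sit. Methyl in place of trifluoromethyl gives an at least 2.2-fold higher number from compound 1 to compound 4 (0.34 log units; beyond the scatter), which leaves compound 1 as the only compound shown with a measured number. The steps among compound 2, compound 3 and compound 4 cannot be read, as both ends of each are limits.

On these data alone, the order among bromo, fluoro and methyl stays unknown. Also open, as far as these compounds go, is whether a nitrile, a methoxy group or an amine at this place would give a measurable value.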